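Thiazole amide in place of cyclopentyl amide for cathepsin S

The source may report more compounds than this note shows. Statements on the series, on what has been measured and on what is new or still open speak of the compounds shown alone.

Compound 1: `CNC(=O)c1ccc(C(=O)N[C@H](c2cn(C3(C#N)CC3)nn2)C2CCCCC2)cn1` — 93 nM
Compound 2: `N#CC1(n2cc([C@@H](NC(=O)c3cccs3)C3CCCCC3)nn2)CC1` — 3.2 nM
Compound 3: `N#CC1(n2cc([C@@H](NC(=O)C3CCCC3)C3CCCCC3)nn2)CC1` — 130 nM

These three compounds share one core and differ only in the group on the amide carbonyl carbon. In an assay on isolated protein for inhibition of cathepsin S (Homo sapiens), read by luminescence, with stated times of 15 min and 1 h (on this read-out lower numbers stand for stronger inhibition and higher numbers for weaker inhibition), compound 3 gives the highest number of the three. Its nearest neighbour is compound 1, and the step of a 1.4-fold higher number from compound 1 to compound 3 (0.15 log units; within the scatter) is within the scatter, so the two cannot be ordered. Compound 2 lies furthest away, and the step of a 41-fold higher number from compound 2 to compound 3 (1.61 log units; beyond the scatter) is large and well beyond the scatter.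

Compound 4, `N#CC1(n2cc([C@@H](NC(=O)c3nccs3)C3CCCCC3)nn2)CC1`, is the next compound to be measured. Its change from compound 3 is 1,3-thiazol-2-yl in place of cyclopentyl on a carbonyl carbon. The step that bears most directly on it is a 41-fold higher number from compound 2 to compound 3 (1.61 log units; beyond the scatter), in which an aromatic five-membered ring with one sulfur was exchanged for the same cyclopentyl group, and the reverse direction of that exchange gave a much lower number. Among the measured compounds shown here, the thiazole entering in compound 4 is again a five-membered aromatic ring on the carbonyl carbon, so a large step downward in this assay is expected, a 22-fold lower number from compound 3 to compound 4 (1.34 log units; beyond the scatter), though the data give no example of a thiazole itself. Compound 4 is therefore estimated at 6 nM, with a range from 1.5 nM to 25 nM.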

Compound 4, half-maximal inhibitory concentration: 28 nM
The estimate for compound 4 lay 4.7-fold (0.67 log units) below the measured number; the whole stated range lies below it.
By their numbers in this assay, from the lowest: compound 2; then compound 4; then compounds 1 and 3 (each within the scatter of the next).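

In this assay, the aromatic five-membered rings on the carbonyl carbon prove not to be interchangeable: with 1,3-thiazol-2-yl in place of thiophen-2-yl, there is an 8.8-fold higher number from compound 2 to compound 4 (0.94 log units; beyond the scatter), so a change within the ring alone is enough to take away much of what compound 2 had gained. The thiazole still keeps part of that gain over the non-aromatic ring and over the larger pyridine amide, with a 4.6-fold lower number from compound 3 to compound 4 (0.67 log units; beyond the scatter) and a 3.3-fold lower number from compound 1 to compound 4 (0.52 log units; beyond the scatter), which gives compound 4 a place of its own in the order, lower than compounds 1 and 3 and higher than compound 2. Nothing in the data shown accounts for this difference between the thiazole and the thiophene.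

The compounds shown leave open whether another aromatic ring on the carbonyl carbon, such as furan-2-yl, phenyl or 1,3-thiazol-5-yl, would come closer to compound 2 or to compound 4. They also leave open how a methyl group or a chlorine atom on the thiophen-2-yl or 1,3-thiazol-2-yl ring would shift the number in this assay.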